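A few compounds are considered here, and "the series" means these few. Any claim that something is new, unique, unknown or untested is made for them only; others in the source may bear on it.

The three measured compounds:

Compound 1, `C=C1CC[C@@H]2[C@](C)(CNCc3ccc(F)cc3)[C@H](O)CC[C@@]2(C)[C@@H]1/C=C/C1=CCOC1=O`, gives 350 nM in a functional assay on BMMC cells (Mus musculus, strain C57BL/6) for inhibition, with stated times of 5 days and 48 h; a lower number here means a stronger inhibitor, a higher number a weaker inhibitor.
Compound 2, `C=C1CC[C@@H]2[C@](C)(CNCc3ccncc3)[C@H](O)CC[C@@]2(C)[C@@H]1/C=C/C1=CCOC1=O`, gives 2030 nM in this assay.
Compound 3, `C=C1CC[C@@H]2[C@](C)(CNCc3cccs3)[C@H](O)CC[C@@]2(C)[C@@H]1/C=C/C1=CCOC1=O`, gives 1070 nM in this assay.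

Compound 3 stands second highest of the three numbers. Its nearest neighbour is compound 2, and that gap, a 1.9-fold lower number from compound 2 to compound 3 (0.28 log units; within the scatter), lies within the scatter, so no order between them can be claimed. Against compound 1 the step of a 3.1-fold higher number from compound 1 to compound 3 (0.49 log units; beyond the scatter) is beyond the scatter.

Compound 4, `C=C1CC[C@@H]2[C@](C)(CNCc3nccs3)[C@H](O)CC[C@@]2(C)[C@@H]1/C=C/C1=CCOC1=O`, has not yet been measured in this assay. It differs from compound 3 in one place: 1,3-thiazol-2-yl in place of thiophen-2-yl on a saturated chain carbon bound to an amine nitrogen. Among the compounds with values here, no measured step shows this exact change. The closest guide is the pair compound 1 to compound 2, where a 5.8-fold higher number from compound 1 to compound 2 (0.76 log units; beyond the scatter) went with a second ring nitrogen entering as a hydrogen-bond acceptor, and the steps from compound 1 to compound 3 and from compound 2 to compound 3 bracket compound 3 between those two. On that basis a modest rise in the number is expected for compound 4, a 1.5-fold higher number from compound 3 to compound 4 (0.17 log units; within the scatter), though the wide scatter leaves room for no change at all. The estimate for compound 4 is 1600 nM, with a range from 600 nM to 4500 nM.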

Compound 4, half-maximal inhibitory concentration: 700 nM
Estimate against measurement, compound 4: 2.3-fold (0.36 log units) above, within the range that was stated.
By their numbers in this assay, from the lowest: compounds 1, 4, 3 and 2 (each within the scatter of the next, the first and the last beyond it).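

In this assay, the step of a 1.5-fold lower number from compound 3 to compound 4 (0.18 log units; within the scatter) lies within the scatter, so adding a ring nitrogen to the five-membered ring gives no readable order between 1,3-thiazol-2-yl and thiophen-2-yl at this position. The step of a 2.0-fold higher number from compound 1 to compound 4 (0.30 log units; within the scatter) also lies within the scatter, while the step of a 2.9-fold lower number from compound 2 to compound 4 (0.46 log units; beyond the scatter) lies beyond it, so compound 2 and compound 4 both carry a ring nitrogen yet are separated, and a ring nitrogen alone does not set the number here. Nothing measured on these compounds accounts for these steps.

As far as these compounds go, it remains open where a plain phenyl group, a pyridin-2-yl group or a 1,3-oxazol-2-yl group would fall. The compounds shown also leave open whether a methyl group on the 1,3-thiazol-2-yl ring would change the number.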